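This account rests on a few compounds, and the source may have more. Where it says the series, first, only, none or still open, it means among the compounds named here.

The measured compounds in this study:

compound 1, `O=S(=O)(/C=C/c1ccc(F)cc1)Cc1ccc(Nc2ncnc3ccccc23)cc1`, 100000 nM
compound 2, `O=S(=O)(/C=C/c1ccc(Cl)cc1)Cc1ccc(Nc2ncnc3ccccc23)cc1`, 77000 nM
compound 3, `O=S(=O)(/C=C/c1ccc(F)cc1F)Cc1ccc(Nc2ncnc3ccccc23)cc1`, 86000 nM

All three were tested in a functional assay on SW-620 cells (Homo sapiens); on this read-out higher numbers stand for weaker inhibition of growth and lower numbers for stronger inhibition of growth. Compound 2 differs from compound 1 by chloro in place of fluoro on an aromatic carbon, and that exchange gave a 1.3-fold lower number from compound 1 to compound 2 (0.11 log units; within the scatter). Compound 3 differs from compound 1 by fluoro in place of hydrogen on an aromatic carbon, and its value sits within the scatter of both other compounds.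

The compound still to be measured, compound 4, `O=S(=O)(/C=C/c1ccc(F)cc1Cl)Cc1ccc(Nc2ncnc3ccccc23)cc1`, differs from compound 3 by chloro in place of fluoro on an aromatic carbon. Among the compounds with values here, this is the same kind of change as the one from compound 1 to compound 2, but its surroundings differ: in compound 1 the exchanged group sits para to a large group, whereas in compound 3 it sits ortho to a large group and meta to a fluoro group. Within the data shown here, the only measured example of this exchange, a 1.3-fold lower number from compound 1 to compound 2 (0.11 log units; within the scatter), lay within the scatter, so a step of a similar size is expected here. Compound 4 is expected to show a 1.2-fold lower number from compound 3 to compound 4 (0.09 log units; within the scatter). The estimate for compound 4 in this assay is 70000 nM, likely between 30000 nM and 150000 nM.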

Compound 4, concentration for 50% growth inhibition: 100000 nM
Estimate against measurement, compound 4: 1.4-fold (0.15 log units) below; low and high end bracket the measured number.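

In this assay, chloro in place of fluoro on an aromatic carbon, here ortho to a large group, gives a 1.2-fold higher number from compound 3 to compound 4 (0.07 log units; within the scatter), and this step does not differ from the earlier example of the same exchange by more than the usual scatter: the same change on two cores in this assay, a 1.3-fold lower number (0.11 log units; within the scatter) from compound 1 to compound 2 and a 1.2-fold higher number (0.07 log units; within the scatter) from compound 3 to compound 4, 1.5-fold (0.18 log units) apart, within the scatter of two such steps. The two other new comparisons, a 1.3-fold higher number from compound 2 to compound 4 (0.11 log units; within the scatter) and no change at the digits printed from compound 1 to compound 4 (within the scatter), also lie within the scatter, so all four compounds read alike on this measure. The exchange therefore left the number unchanged within the scatter on both cores, but that does not show a real effect being carried from one core to the other, since steps this small cannot be told apart from the noise of repeated measurements.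

The compounds shown contain only fluoro and chloro on this aromatic ring, so it remains open whether a different group there, such as a methoxy group or an amine, would shift the number. On these data alone, whether any change elsewhere on the shared core would do so also remains open.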